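Hydroxy to Nitro on the Attached Phenyl Group

This account rests on a few compounds, and the source may have more. Where it says the series, first, only, none or still open, it means among the compounds named here.

Measured so far:
compound 1, `Cc1cc(-c2ccc(O)cc2)c2ncc(CSCCc3ccccc3)n2c1`: 20 ug/mL
compound 2, `Cc1cc(-c2cccc(C#N)c2)cn2c(CSCCc3ccccc3)cnc12`: > 100 ug/mL, a limit of the assay
compound 3, `Cc1cc(-c2cccc(O)c2)cn2c(CSCCc3ccccc3)cnc12`: 20 ug/mL

In an ADME assay on HEL cells (Homo sapiens) for cytotoxicity, with a stated time of 3 days (a lower number here means that less compound is tolerated, a higher number that more compound is tolerated), compound 1 gives 20 ug/mL. Compound 3 gives 20 ug/mL, so compound 1 stands level with compound 3, within the scatter. Compound 2 reaches only a limit of the assay, > 100 ug/mL. Compound 4, `Cc1cc(-c2cccc([N+](=O)[O-])c2)c2ncc(CSCCc3ccccc3)n2c1`, has not yet been measured; it differs from compound 1 by 3-nitrophenyl in place of 4-hydroxyphenyl on an aromatic carbon. Within the data shown here, one measured step bears on this change: an at least 5.0-fold lower number from compound 2 to compound 3 (0.69 log units; beyond the scatter), in which a hydroxy replaces a cyano on the attached phenyl group and the tolerated amount falls. Compound 4, like compound 2, carries no hydroxy on that phenyl group, so an upward step is expected, estimated as a 4.0-fold higher number from compound 1 to compound 4 (0.60 log units; beyond the scatter). Since compound 2 sits at the limit of > 100 ug/mL in this assay, at which 1 of the 3 values shown sits, compound 4 may likewise be reported only as a limit. Compound 4 is therefore expected to give about 80 ug/mL, with a range from 30 ug/mL to 200 ug/mL.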

Compound 4, minimum cytotoxic concentration: 100 ug/mL
Compound 4: middle estimate off by 1.3-fold (0.10 log units), on the low side, within the range that was stated.
By their numbers in this assay, from the lowest: compounds 1 and 3 (each within the scatter of the next); then compound 4.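

In this assay, among these compounds, the step to the 3-nitrophenyl group is a 5.0-fold higher number from compound 1 to compound 4 (0.70 log units; beyond the scatter), the first measured change at this position on an aromatic carbon two atoms from the ring nitrogen. Among the compounds shown here, until now, this position held only the 4-hydroxyphenyl group, and the one step that removed a hydroxy came from compounds with the phenyl group elsewhere on the core. Compound 4 gives a plain number, and the one limit among the compounds shown stays with compound 2: the limit of > 100 ug/mL in this assay, at which 1 of the 4 values shown sits.

The compounds shown leave open which part of the change carries the step, as the hydroxy leaves, the nitro enters and the substituent's place on the phenyl ring shifts all at once. Also open, from the compounds shown here alone, is how an amine or a carboxylic acid on that phenyl group would read in this assay.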